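One Methoxy Added to a Weakly Active Compound

The compounds below may be only part of what the source reports. "The series", "measured", "known", "first", "only" and "open" are said of these compounds alone.

So far, two compounds have been tested in a functional assay on A549 cells (Homo sapiens) for inhibition, with a stated time of 48 h; on this read-out higher numbers stand for weaker inhibition and lower numbers for stronger inhibition. Going by the values given here, compound 2 `C[S+]([O-])/C=C/c1cc(=O)c2ccccc2o1` gives 10000 nM in this assay, and that is the only plain number in the set. Compound 1 `COc1ccc2c(=O)cc(/C=C/[S+](C)[O-])oc2c1OC` reaches only a limit of this assay, > 10000 nM, which is not a number; this is the limit of > 10000 nM in this assay, at which 1 of the 2 values shown sits. Among the compounds with values here, compound 2 therefore stands at the single measured number, with the other value being a limit. Compound 3 `COc1ccc2c(=O)cc(/C=C/[S+](C)[O-])oc2c1` has not yet been measured; it differs from compound 2 by methoxy in place of hydrogen on an aromatic carbon. Within the data shown here, no two measured compounds differ in just one place, so no measured step shows what such a change does here. Because compound 2 gives 10000 nM, compound 3 is expected to stay in the same weak region, and the step of no change at the digits printed from compound 2 to compound 3 (within the scatter) is expected to be none beyond the scatter. Compound 3 is thus estimated at 10000 nM, in a range from 4000 nM to 25000 nM, with a real chance that only a limit is reported.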

Compound 3, half-maximal inhibitory concentration: 10500 nM
For compound 3 the middle estimate is 1.1-fold (0.02 log units) below the measured one; low and high end bracket the measured number.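

In this assay, going by these compounds alone, putting methoxy in place of hydrogen on an aromatic carbon gives a 1.1-fold higher number from compound 2 to compound 3 (0.02 log units; within the scatter) and so provides the first readable step in this set. At this place, meta to a fused ring and para to a fused ring, the two compounds cannot be told apart in this read-out, since the step lies within the scatter. Compound 1 gives > 10000 nM which is a limit of the assay and not a number, so its step to compound 3 cannot be read: the limit of > 10000 nM in this assay, at which 1 of the 3 values shown sits.

As far as these compounds go, whether an amine, a carboxylic acid or a longer chain such as ethoxy at this same place would move the number beyond the scatter remains open. From the compounds shown here alone, it is also open whether methoxy would behave the same way on the other carbons of this ring.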